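This account rests on a few compounds, and the source may have more. Where it says the series, first, only, none or still open, it means among the compounds named here.

In a functional assay on U-937 cells (Homo sapiens), read by cAMP accumulation (on this read-out lower numbers stand for an effect already at smaller amounts and higher numbers for an effect only at larger amounts of compound), compound 3 `CCc1nn(C2CCCC2)c2c1CCN(c1cccc(Cl)c1)C2=O` gives 41 nM, level with compound 2 `CCc1nn(C2CCCC2)c2c1CCN(c1ccsc1)C2=O` at 36 nM, while compound 1 `CCc1nn(C2CCCC2)c2c1CCN(c1cccs1)C2=O` stands far lower at 1 nM. Compound 4 `CCc1nn(C2CCCC2)c2c1CCN(c1cccnc1)C2=O` has pyridin-3-yl in place of 3-chlorophenyl on an amide-type nitrogen in a ring. The closest guide is a 1.1-fold higher number from compound 2 to compound 3 (0.06 log units; within the scatter), a swap of one ring for another that stays within the scatter. Among the measured compounds shown here, the large steps, a 36-fold higher number from compound 1 to compound 2 (1.56 log units; beyond the scatter) and a 41-fold higher number from compound 1 to compound 3 (1.61 log units; beyond the scatter), both start from thiophen-2-yl, so that group is the exception, and no measured compound carries pyridin-3-yl. Hence no step beyond the scatter is expected, and the estimated change is a 1.5-fold higher number from compound 3 to compound 4 (0.17 log units; within the scatter). For compound 4 the expected value is 60 nM, within an estimated range of 15 nM to 240 nM.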

Compound 4, half-maximal effective concentration: 17 nM
Compound 4: middle estimate off by 3.5-fold (0.55 log units), on the high side; low and high end bracket the measured number.
By their numbers in this assay, from the lowest: compound 1; then compound 4; then compounds 2 and 3 (each within the scatter of the next).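

In this assay the ring on the amide-type nitrogen matters even among the rings that had looked level: pyridin-3-yl gives a 2.4-fold lower number from compound 3 to compound 4 (0.38 log units; beyond the scatter) and a 2.1-fold lower number from compound 2 to compound 4 (0.33 log units; beyond the scatter) as modest steps, both beyond the scatter. Even so, a 17-fold higher number from compound 1 to compound 4 (1.23 log units; beyond the scatter) is a large step that keeps thiophen-2-yl well apart from the other three rings. Nothing available explains these differences. From the compounds shown here alone, what remains open is whether pyridin-2-yl, pyridin-4-yl or a phenyl ring carrying a carboxylic acid in this place would come closer to compound 1.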